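Working notes: compound 3 from compound 1

The source may report more compounds than this note shows. Statements on the series, on what has been measured and on what is new or still open speak of the compounds shown alone.

Compound 1 `Nc1c2c(=O)[nH]c(-c3ccccc3)cc2nn1-c1ccccc1` is the reference of the pair measured so far. In an assay on isolated protein for inhibition of ribosomal protein S6 kinase alpha-1 (Homo sapiens), read by mobility shift assay, tested at 30 uM (on this read-out higher numbers stand for more inhibition at the one concentration tested (going by the name of the read-out) and lower numbers for less inhibition), compound 1 gives 38%, the higher of the two numbers. Compound 2 `COc1ccccc1-c1cc2nn(-c3ccccc3)c(N)c2c(=O)[nH]1` carries methoxy in place of hydrogen on an aromatic carbon; in this assay compound 2 gives 3%, so a number 35 percentage points lower from compound 1 to compound 2 (beyond the scatter). Compound 3 `CN1CCN(c2ccc(-c3cc4nn(-c5ccccc5)c(N)c4c(=O)[nH]3)cc2)CC1` differs from compound 1 by 4-methylpiperazin-1-yl in place of hydrogen on an aromatic carbon. Among the compounds with values here, the only measured step, that from compound 1 to compound 2, also adds a group to an aromatic carbon of this ring, but a different group at a different place, so it bears on compound 3 only loosely; it does show that a single substituent on this ring can move the number a great deal. No closer comparison exists. The estimate for compound 3 is a number 8 percentage points lower from compound 1 to compound 3 (within the scatter), with a wide range: compound 3 is expected to give about 30%, between 5% and 60%.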

Compound 3, a percentage reported as inhibition, at one concentration (the size of the read-out at that concentration, not a potency): 19%
The estimate for compound 3 lay 11 percentage points above the measured number, and the stated range covers the measured number.
By their numbers in this assay, from the lowest: compound 2; then compound 3; then compound 1.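

In this assay, placing 4-methylpiperazin-1-yl on an aromatic carbon para to a large group gives a number 19 percentage points lower from compound 1 to compound 3 (beyond the scatter) and so shows that this place responds to a substituent carrying a six-membered non-aromatic ring with 2 hetero atoms. With this group in place, compound 3 gives 19% and still keeps a number above zero, so a group of 7 heavy atoms here does not remove inhibition entirely at the one concentration tested. No evidence at hand accounts for this step.

As far as these compounds go, it remains open whether a simple amine such as dimethylamino or a carboxylic acid at this same place would bring the number closer to that of compound 1. Also open, from the compounds shown here alone, is whether a longer chain between this ring and the piperazine would change the number.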